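A Boron-Containing Chalcone Series Tested for Cytotoxicity

The source may report more compounds than this note shows. Statements on the series, on what has been measured and on what is new or still open speak of the compounds shown alone.

Of the compounds shown here, three sharing one core have been measured in a toxicity assay on WI-38 cells (Homo sapiens) for cytotoxicity, read by MTT assay, with a stated time of 48 h; a higher number here means a weaker inhibitor, a lower number a stronger inhibitor. Compound 1 `O=C(/C=C/c1ccc2c(c1)B(O)OC2)c1ccc(-c2ccccc2)cc1` gives 18300 nM. For the measured compounds named here, compound 3 `CSc1ccc(C(=O)/C=C/c2ccc3c(c2)B(O)OC3)cc1` gives 54300 nM, and the step of a 3.0-fold higher number from compound 1 to compound 3 (0.47 log units; beyond the scatter) is the only one-point change measured so far. Compound 2 `O=C(/C=C/c1ccc2c(c1)B(O)OC2)c1cccnc1` gives 76200 nM, the highest of the three numbers; it sits within the scatter of compound 3 but beyond it relative to compound 1.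

Compound 4 `Cc1cccc(C(=O)/C=C/c2ccc3c(c2)B(O)OC3)c1` has not yet been tested. It differs from compound 2 by 3-methylphenyl in place of pyridin-3-yl on a carbonyl carbon. Going by the values given here, no measured step speaks to this exact change. The step from compound 1 to compound 3 concerns a different position on the aryl attached to the carbonyl and was modest; the values of compound 1 and compound 2 show that an aryl of carbon only at this carbonyl can sit well below the pyridin-3-yl compound, but a second position also changes between them, so that comparison is loose. On this basis compound 4 is expected to give a lower number than compound 2, by a modest step of a 1.9-fold lower number from compound 2 to compound 4 (0.28 log units; within the scatter), with wide uncertainty. The estimate for compound 4 is 40000 nM, in a range of 15000 nM to 110000 nM.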

Compound 4, half-maximal inhibitory concentration: 16700 nM
Compound 4: the middle estimate sits 2.4-fold (0.38 log units) above what was measured, within the range that was stated.
By their numbers in this assay, from the lowest: compounds 4 and 1 (each within the scatter of the next); then compounds 3 and 2 (each within the scatter of the next).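

In this assay, for the compounds shown here, the swap of pyridin-3-yl for 3-methylphenyl on the carbonyl carbon is the first one-point change measured at this place, and it gives a 4.6-fold lower number from compound 2 to compound 4 (0.66 log units; beyond the scatter). Going by these compounds alone, the only earlier one-point change, a 3.0-fold higher number from compound 1 to compound 3 (0.47 log units; beyond the scatter), exchanged one group for another on an aromatic carbon of the aryl and left that ring itself in place, whereas this step shows that replacing the ring on the carbonyl carbon, with all else in the shared core held fixed, is enough on its own to move the number beyond the scatter. No measurement offered here bears on the reason for this step, so the result stands as an observation only.

The step joins two changes in one, the loss of the ring nitrogen and the arrival of the methyl, and the compounds shown do not separate them; a plain phenyl on this carbonyl carbon would be the compound to do so. From the compounds shown here alone, it also remains open how an amine or a carboxylic acid on this aryl would read in this assay.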